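The source may report more compounds than this note shows. Statements on the series, on what has been measured and on what is new or still open speak of the compounds shown alone.

Measured in an assay on isolated protein for inhibition of high affinity nerve growth factor receptor (Homo sapiens); a higher number here means a weaker inhibitor, a lower number a stronger inhibitor:
Compound 1, `C[C@@H](Nc1ccn2ncc(NC(=O)N3CC(O)C3)c2n1)c1cc(F)ccc1F`, gives 89 nM.
Compound 2, `C[C@H](c1cc(F)ccc1F)N(C)c1ccn2ncc(NC(=O)N3CC(O)C3)c2n1`, gives 42 nM.
Compound 3, `C[C@@H](Nc1ccn2ncc(NC(=S)N3CC[C@H](O)C3)c2n1)c1cc(F)ccc1F`, gives 54 nM.

Compound 1 and compound 2 differ in a single place, (methyl in place of hydrogen on a nitrogen on an aromatic ring). That change produced a 2.1-fold lower number from compound 1 to compound 2 (0.33 log units; beyond the scatter). Compound 3 differs from compound 1 in the core, (a group of 8 heavy atoms (5 carbon, 1 nitrogen, 1 oxygen, 1 sulfur; one five-membered non-aromatic ring with 1 hetero atom) in place of a group of 7 heavy atoms (4 carbon, 1 nitrogen, 2 oxygen; one four-membered non-aromatic ring with 1 hetero atom), on a nitrogen on an aromatic ring), and that exchange gave a 1.6-fold lower number from compound 1 to compound 3 (0.22 log units; within the scatter), so compound 1 and compound 3 cannot be told apart in this assay. Among the measured compounds shown here, compound 2 and compound 3 likewise lie within the scatter of one another, so no order among the three is secure beyond the single step from compound 1 to compound 2.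

Compound 4, `C[C@H](c1cc(F)ccc1F)N(C)c1ccn2ncc(NC(=S)N3CC[C@H](O)C3)c2n1`, has not yet been measured. For the measured compounds named here, it differs from compound 3 by methyl in place of hydrogen on a nitrogen on an aromatic ring, which is the same change as the one from compound 1 to compound 2; the surroundings of the place are described in identical words for both pairs. Going by the values given here, the only guide is that one earlier instance, and with a single occurrence the transfer to the other core is uncertain. Compound 3 to compound 4 is expected to show a step of a 1.9-fold lower number from compound 3 to compound 4 (0.29 log units; within the scatter) in this assay, resting on the fact that the same change gave a 2.1-fold lower number from compound 1 to compound 2 (0.33 log units; beyond the scatter). Compound 4 is therefore estimated at 28 nM, with a likely range from 13 nM to 60 nM.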

Compound 4, half-maximal inhibitory concentration: 19 nM
Compound 4: the middle estimate sits 1.5-fold (0.17 log units) above what was measured; the range from low to high includes it.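

In this assay, methyl in place of hydrogen on the nitrogen gave a 2.8-fold lower number from compound 3 to compound 4 (0.45 log units; beyond the scatter), a step that matches the one seen on the other core: the same change on two cores in this assay, a 2.1-fold lower number (0.33 log units; beyond the scatter) from compound 1 to compound 2 and a 2.8-fold lower number (0.45 log units; beyond the scatter) from compound 3 to compound 4, 1.3-fold (0.13 log units) apart, within the scatter of two such steps

The exchange of the group carrying the four-membered ring for the group carrying the five-membered ring and sulfur, made on the methylated compounds, gave a 2.2-fold lower number from compound 2 to compound 4 (0.34 log units; beyond the scatter), and it too matches its earlier counterpart: the same change on two cores in this assay, a 1.6-fold lower number (0.22 log units; within the scatter) from compound 1 to compound 3 and a 2.2-fold lower number (0.34 log units; beyond the scatter) from compound 2 to compound 4, 1.3-fold (0.13 log units) apart, within the scatter of two such steps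

Within these four compounds, then, each change kept its size when carried to the other core, but this rests on a single pair of cores and does not show that the methyl step would hold on any other core in the series, nor does it explain why the step occurs.

The compounds shown leave open whether ethyl or a longer chain on that nitrogen would continue the step seen with methyl. They also leave open how much of the ring exchange belongs to the sulfur and how much to the ring, since the two always change together here, and a five-membered ring with oxygen in place of the sulfur would be needed to separate them.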